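The source may hold more compounds than are shown below. What is called first, only, known or untested is meant among the compounds shown, and "the series" means these compounds.

In an assay on HT-29 cells for inhibition of Serine-protein kinase ATM (Homo sapiens), read by fluorescence, with a stated time of 1 h (a lower number here means a stronger inhibitor, a higher number a weaker inhibitor), three compounds have been measured:

compound 1 `CCC(CC)CNc1c(C(N)=O)cnc2ccc(-c3ccncc3)cc12` gives 418 nM
compound 2 `CCC(CC)CNc1c(C(N)=O)cnc2ccc(-c3ccc(C)nc3)cc12` gives 50 nM
compound 3 `CCC(CC)CNc1c(C(N)=O)cnc2ccc(-c3ccc(CO)nc3)cc12` gives 87 nM

Compound 3 stands second highest of the three numbers in this assay; its nearest neighbour is compound 2, its furthest compound 1. Two steps from compound 1 changed the ring on the shared core: an 8.4-fold lower number from compound 1 to compound 2 (0.92 log units; beyond the scatter) and a 4.8-fold lower number from compound 1 to compound 3 (0.68 log units; beyond the scatter), both beyond the scatter. The step between compound 2 and compound 3, a 1.7-fold higher number from compound 2 to compound 3 (0.24 log units; within the scatter), lay within the scatter.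

Compound 4 `CCC(CC)CNc1c(C(N)=O)cnc2ccc(-c3ccc(COC)nc3)cc12` differs from compound 3 by methyl in place of hydrogen on an oxygen on a saturated carbon. For the measured compounds named here, the only measured step that bears on this position is the one from compound 2 to compound 3, which was within the scatter; no step touching the oxygen itself has been measured. The expectation in this assay is therefore a step of a 1.0-fold higher number from compound 3 to compound 4 (0.01 log units; within the scatter), not beyond the scatter in either direction. Compound 4 is estimated at 90 nM, with a range from 40 nM to 200 nM.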

Compound 4, half-maximal inhibitory concentration in the Serine-protein kinase ATM assay: 45 nM
Compound 4: middle estimate off by 2.0-fold (0.30 log units), on the high side; low and high end bracket the measured number.
By their numbers in the Serine-protein kinase ATM assay, from the lowest: compounds 4, 2 and 3 (each within the scatter of the next); then compound 1.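

In the Serine-protein kinase ATM assay compound 4 gives 45 nM; methyl in place of hydrogen on the oxygen, the first change made at that atom, stays within the scatter (a 1.9-fold lower number from compound 3 to compound 4 (0.29 log units; within the scatter)), and the methoxymethyl and methyl groups also stand within the scatter of each other (a 1.1-fold lower number from compound 2 to compound 4 (0.05 log units; within the scatter)). In the Serine-protein kinase ATM assay, the 6-(methoxymethyl)pyridin-3-yl group keeps the step beyond the scatter from the pyridin-4-yl group (a 9.3-fold lower number from compound 1 to compound 4 (0.97 log units; beyond the scatter)), as the methyl and hydroxymethyl groups did. In a physicochemical assay for lipophilicity, using the shake flask method, measured as octanol-water partition, at pH 7.4 (a lower number here means a more polar compound, a higher number a more lipophilic compound), compound 3 gives 3.7, and the same change on the oxygen gives a step beyond the scatter (a number at least 0.60 log units higher from compound 3 to compound 4 (beyond the scatter)). In the physicochemical assay compound 4 gives > 4.3, which is a limit of the assay, not a number: the limit of > 4.3 in the physicochemical assay, at which 1 of the 2 values shown sits.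

The compounds shown leave open whether an amine, a carboxylic acid or a longer ether chain on that saturated carbon would stay within the same range in the Serine-protein kinase ATM assay. They also leave open whether methoxymethyl would act alike on the pyridin-4-yl group of compound 1.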